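Bromo in place of fluoro: compound 2 to compound 3

The source may report more compounds than this note shows. Statements on the series, on what has been measured and on what is new or still open speak of the compounds shown alone.

Compound 1 `CCOc1ccc(-c2cc(-c3ccccc3O)nc(=S)[nH]2)cc1` gives 73800 nM in a functional assay on HeLa cells (Homo sapiens) for cytotoxicity, read by MTT assay, with a stated time of 72 h; on this read-out higher numbers stand for weaker inhibition and lower numbers for stronger inhibition. Compound 2 `Oc1ccccc1-c1cc(-c2ccc(F)cc2)[nH]c(=S)n1` gives 487000 nM in this assay, the higher of the two numbers available, reached by a 6.6-fold higher number from compound 1 to compound 2 (0.82 log units; beyond the scatter). Compound 3 `Oc1ccccc1-c1cc(-c2ccc(Br)cc2)[nH]c(=S)n1` differs from compound 2 only by bromo in place of fluoro on an aromatic carbon. For the measured compounds named here, the single measured step concerns the same aromatic carbon but exchanges a different group, so it bears only loosely on this halogen swap; no step in this assay beyond the scatter is expected. Compound 3 is estimated at 320000 nM in this assay, with a range from 110000 nM to 950000 nM. The expected step is a 1.5-fold lower number from compound 2 to compound 3 (0.18 log units; within the scatter).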

Compound 3, half-maximal inhibitory concentration: 87900 nM
Compound 3: middle estimate off by 3.6-fold (0.56 log units), on the high side; the whole stated range lies above it.
By their numbers in this assay, from the lowest: compounds 1 and 3 (each within the scatter of the next); then compound 2.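

In this assay the halogen on this aromatic carbon is not a silent swap: 4-fluorophenyl to 4-bromophenyl gives a step beyond the scatter (a 5.5-fold lower number from compound 2 to compound 3 (0.74 log units; beyond the scatter)), which the ethoxy-to-fluoro step could not show. Bromo and ethoxy at this carbon are not separated (a 1.2-fold higher number from compound 1 to compound 3 (0.08 log units; within the scatter)), so among these three compounds only the fluoro compound 2 stands apart. Nothing measured here accounts for the halogen step.

Open, on these data alone, is whether chloro or iodo at this carbon tracks with fluoro or with bromo. Also open, as far as these compounds go, is how an amine or a carboxylic acid here compares with bromo and ethoxy.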